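A few compounds are considered here, and "the series" means these few. Any claim that something is new, unique, unknown or untested is made for them only; others in the source may bear on it.

Working notes on the series, all in a functional assay on the whole organism (Hindlimb, strain albino) with Mus musculus as the target, in the maximal electroshock model, with a stated time of 0.5 h; on this read-out lower numbers stand for an effect already at smaller amounts and higher numbers for an effect only at larger amounts of compound. Compound 3 (`CC(=O)N1N=C(Nc2nc3ccccc3s2)CC1OC1=CC=C1`) gives 382 umol/kg, within the scatter of compound 2 (`CC(=O)N1N=C(Nc2nc3ccccc3s2)CC1c1ccc(Cl)cc1`) at 209 umol/kg, while compound 1 (`COc1ccc(C2CC(Nc3nc4ccc([N+](=O)[O-])cc4s3)=NN2C(C)=O)cc1`) gives 145 umol/kg. That number lies beyond the scatter from compound 3, on the lower side. Next is compound 4 (`COc1ccc(C2CC(Nc3nc4ccccc4s3)=NN2C(C)=O)cc1`), which differs from compound 3 as follows: a group of 8 heavy atoms (7 carbon, 1 oxygen; one six-membered aromatic ring of carbon only) in place of a group of 5 heavy atoms (4 carbon, 1 oxygen; one four-membered non-aromatic ring of carbon only), on a saturated ring carbon. Within the data shown here, the one measured step bearing on this is a 1.8-fold higher number from compound 2 to compound 3 (0.26 log units; within the scatter), an exchange of the same kind in the opposite sense. Compound 1, at 145 umol/kg, also carries 4-methoxyphenyl, but its core differs elsewhere. A small move to a lower number is therefore expected, near the edge of the scatter: a 1.9-fold lower number from compound 3 to compound 4 (0.28 log units; within the scatter). For compound 4 the estimated value is 200 umol/kg, with an expected range of 110 umol/kg to 360 umol/kg.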

Compound 4, dose for half-maximal effect: 226 umol/kg
Estimate against measurement, compound 4: 1.1-fold (0.05 log units) below; low and high end bracket the measured number.
By their numbers in this assay, from the lowest: compounds 1, 2, 4 and 3 (each within the scatter of the next, the first and the last beyond it).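

In this assay, 4-methoxyphenyl on the saturated ring carbon gives the first direct reading against the four-membered ring group (a 1.7-fold lower number from compound 3 to compound 4 (0.23 log units; within the scatter)) and, with methoxy in place of chloro on an aromatic carbon, shows a step within the scatter (a 1.1-fold higher number from compound 2 to compound 4 (0.03 log units; within the scatter)). Hydrogen in place of nitro on an aromatic carbon is the first step read at that second place in the series, and it also stays within the scatter (a 1.6-fold higher number from compound 1 to compound 4 (0.19 log units; within the scatter)). No measured evidence accounts for these results.

Going by these compounds, whether an amine or a carboxylic acid in place of nitro would give a step beyond the scatter remains open.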